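The compounds below may be only part of what the source reports. "The series", "measured", "known", "first", "only" and "open" are said of these compounds alone.

Measured in a functional assay for inhibition, with Homo sapiens as the target; on this read-out lower numbers stand for stronger inhibition and higher numbers for weaker inhibition:
- Compound 1 `COc1cccc(Nc2nccc(-c3ccccn3)n2)c1`: 200 nM
- Compound 2 `COc1cccc(Nc2nccc(-c3cccs3)n2)c1`: 900 nM
- Compound 3 `COc1cccc(Nc2nccc(-c3sccc3C)n2)c1`: > 24000 nM

Compound 3 is the weakest of the three. Compound 3 gives > 24000 nM, which is a limit of the assay and not a number.

Compound 4 `COc1cccc(Nc2nccc(-c3ccc(C)s3)n2)c1` has the same atoms as compound 3, joined differently, with 5-methylthiophen-2-yl in place of 3-methylthiophen-2-yl on an aromatic carbon.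

For the measured compounds named here, three measured steps bear on this change. Replacing pyridin-2-yl with thiophen-2-yl cost only a modest amount, a 4.5-fold higher number from compound 1 to compound 2 (0.65 log units; beyond the scatter). Adding the methyl of 3-methylthiophen-2-yl cost far more, an at least 26-fold higher number from compound 2 to compound 3 (1.42 log units; beyond the scatter), and the whole change from pyridin-2-yl gives an at least 120-fold higher number from compound 1 to compound 3 (2.07 log units; beyond the scatter).

Going by the values given here, no measured compound carries 5-methylthiophen-2-yl, so that large loss may not carry over, and compound 4 is expected to lie nearer compound 2 at 900 nM. The expected change in this assay is a large one towards stronger inhibition: an at least 16-fold lower number from compound 3 to compound 4 (1.20 log units; beyond the scatter). Compound 4 is estimated at 1500 nM, within an expected range of 300 nM to 8000 nM.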

Compound 4, half-maximal inhibitory concentration: 2300 nM
Compound 4: the middle estimate sits 1.5-fold (0.19 log units) below what was measured; measured number inside the range.
By their numbers in this assay, from the lowest: compound 1; then compound 2; then compound 4. At a limit, above all of these: compound 3.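

Moving the methyl, with the atoms otherwise unchanged, gives an at least 10-fold lower number from compound 3 to compound 4 (1.01 log units; beyond the scatter), so in this assay the large loss seen with 3-methylthiophen-2-yl comes from where the methyl sits, not from the presence of a methyl alone. Even 5-methylthiophen-2-yl has some cost, with a 2.6-fold higher number from compound 2 to compound 4 (0.41 log units; beyond the scatter), and against pyridin-2-yl the change amounts to a 12-fold higher number from compound 1 to compound 4 (1.06 log units; beyond the scatter). The first of these steps gives only a minimum size, since compound 3 stands at a limit and not at a number: the limit of > 24000 nM in this assay, at which 1 of the 4 values shown sits.

On these data alone, it remains open whether an ethyl group, an amine or a carboxylic acid in place of the methyl of 5-methylthiophen-2-yl would give a lower or a higher number. As far as these compounds go, whether a methyl on pyridin-2-yl would show the same dependence on its place also remains open.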